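A few compounds are considered here, and "the series" means these few. Any claim that something is new, unique, unknown or untested is made for them only; others in the source may bear on it.

Notes on the series. In a functional assay with Rattus norvegicus as the target, read by electrophysiology (a lower number here means that less compound is needed, a higher number that more compound is needed for the effect), compound 1 (`CNC(C(=O)O)c1cc(O)no1`) gives 140000 nM and compound 2 (`CCNC(C(=O)O)c1cc(O)no1`) gives 320000 nM. For the measured compounds named here, compound 2 therefore holds the higher of the two numbers measured so far, meaning more compound is needed for the effect.

Compound 3 (`O=C(O)C(NCc1ccccc1)c1cc(O)no1`) is the next to consider. Its difference from compound 2 is phenyl in place of methyl on a saturated chain carbon bound to an amine nitrogen, with phenyl in place of methyl on a saturated chain carbon bound to an amine nitrogen.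

Going by the values given here, only one measured step bears on this change: a 2.3-fold higher number from compound 1 to compound 2 (0.36 log units; beyond the scatter). It is modest but beyond the scatter, and it comes from extending the same chain with methyl in place of hydrogen. Among the compounds with values here, a single step makes no trend, and no measured compound carries a ring on this chain, so the direction is a tentative expectation and the size is poorly defined.

In this assay a further rise is expected, with the estimated change being a 2.5-fold higher number from compound 2 to compound 3 (0.40 log units; beyond the scatter), about the size of the measured step or slightly more. For compound 3 the estimated value is 800000 nM, with an expected range from 250000 nM to 3000000 nM.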

Compound 3, half-maximal effective concentration: > 1000000 nM
Compound 3 ended at the assay's limit; the forecaster's own chance of this, stated with the estimate: 35%; middle value at least 1.2-fold (0.09 log units) away from the limit.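

In this assay compound 3 gives > 1000000 nM, which is a limit of the assay and not a number. Phenyl in place of methyl on a saturated chain carbon bound to an amine nitrogen brings an at least 3.1-fold higher number from compound 2 to compound 3 (0.49 log units; beyond the scatter), and phenyl in place of hydrogen at that place brings an at least 7.1-fold higher number from compound 1 to compound 3 (0.85 log units; beyond the scatter), so the rise seen so far only with methyl, a 2.3-fold higher number from compound 1 to compound 2 (0.36 log units; beyond the scatter), also appears with an aromatic ring, and the order hydrogen, methyl, phenyl holds across all three compounds with none against it. The full size of both new steps stays unknown, and a comparison of their size with the methyl step cannot be settled, because compound 3 stands at the limit: the limit of > 1000000 nM in this assay, at which 1 of the 3 values shown sits.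

On these data alone, whether the rise follows the ring itself or simply the larger group stays open, and a cyclohexyl or a plain propyl chain at this place would separate the two readings. Also open is how the shared core behaves with a primary amine, or with a phenyl carrying a hydroxyl or a methoxy group, since the series shown has only unsubstituted carbon groups here.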